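Swapping the halogen-bearing ring on a chalcone core

A few compounds are considered here, and "the series" means these few. Any claim that something is new, unique, unknown or untested is made for them only; others in the source may bear on it.

Compound 1, with the structure `COc1ccc(C(=O)/C=C/c2ccc(Br)cc2)c2c1C=CC(C)(C)O2`, was tested in a functional assay on SW-620 cells (Homo sapiens) for antiproliferative activity, read by MTT assay, with a stated time of 24 h; on this read-out higher numbers stand for weaker inhibition and lower numbers for stronger inhibition. In this assay compound 1 gives only a limit, > 10000 nM, and not a number. Two other members of the series share the same core. Compound 2, `COc1ccc(C(=O)/C=C/c2ccc3ccccc3c2)c2c1C=CC(C)(C)O2`, gives 2140 nM in this assay. Compound 3, `COc1ccc(C(=O)/C=C/c2ccc(OC)c(OC)c2OC)c2c1C=CC(C)(C)O2`, gives only a limit in this assay, > 10000 nM. So compound 1 sits at the edge of what the assay can report, alongside compound 3, as shown by the limit of > 10000 nM in this assay, at which 2 of the 3 values shown sit, while compound 2 is the only one of the three with a measured number.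

Compound 4, `COc1ccc(C(=O)/C=C/c2ccccc2Cl)c2c1C=CC(C)(C)O2`, has not yet been tested. It differs from compound 1 in one place: 2-chlorophenyl in place of 4-bromophenyl on a double-bonded chain carbon bound to a double-bonded chain carbon. Since compound 1 gives only a limit, the size of the step to compound 4 cannot be read from a measured pair, and no direction beyond the usual scatter is expected. The step that the limit leaves unreadable from compound 1 to compound 4 is the estimate made here. Compound 4 is expected to give about 12000 nM in this assay, within a range from 3000 nM to 50000 nM.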

Compound 4, half-maximal inhibitory concentration: > 10000 nM
Compound 4: a limit, no number (the forecaster's own chance of this, stated with the estimate: 60%); the middle value does not contradict the limit.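

Compound 1 and compound 4 both give only a limit in this assay, so no step between them can be read: the limit of > 10000 nM in this assay, at which 3 of the 4 values shown sit.

The compounds shown leave open whether 2-chlorophenyl and 4-bromophenyl on the shared core differ at all in this assay, and by how much.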